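Swapping phenyl for cyclohexyl on a solubility floor

The source may hold more compounds than are shown below. What is called first, only, known or untested is meant among the compounds shown, and "the series" means these compounds.

Readings in a physicochemical assay for solubility, using the shake flask method, measured as kinetic solubility, with a stated time of 2 h, at pH 7.4 (a lower number here means a less soluble compound, a higher number a more soluble compound), for the three measured compounds:
- compound 1 `CN(Cc1ccccc1)c1cc(C(=O)Nc2ccccc2)ncn1` gives < 5000 nM as a limit
- compound 2 `CN(Cc1ccc(F)cc1)c1cc(C(=O)Nc2ccccc2)ncn1` gives < 5000 nM as a limit
- compound 3 `CN(Cc1ccc(C(F)(F)F)cc1)c1cc(C(=O)Nc2ccccc2)ncn1` gives < 5000 nM as a limit

Compound 3 stands at < 5000 nM as a limit of the assay and not as a number. Within the data shown here, it shares this position with the other two compounds, and the whole series so far rests on the limit of < 5000 nM in this assay, at which 3 of the 3 values shown sit, with no order to be read among them.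

Compound 4 `CN(Cc1ccc(C(F)(F)F)cc1)c1cc(C(=O)NC2CCCCC2)ncn1` keeps the rest of compound 3 and changes one group, cyclohexyl in place of phenyl on an amide-type nitrogen in the one difference between them.

The measured steps offer little guidance. There is a step that the two limits leave unreadable from compound 1 to compound 2 and also a step that the two limits leave unreadable from compound 1 to compound 3 as well as a step that the two limits leave unreadable from compound 2 to compound 3 in the data. All three changed a group on an aromatic carbon rather than on the amide-type nitrogen, and none has a readable size. No direction can be drawn from them.

The expected change is a step that the limit leaves unreadable from compound 3 to compound 4 as an estimate with no firm direction, and nothing beyond the scatter can be argued. The estimate for compound 4 is 4000 nM within an expected range of 1500 nM to 15000 nM in this assay and a reading of only a limit is also expected to be likely.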

Compound 4, solubility: 5000 nM
Estimate against measurement, compound 4: 1.3-fold (0.10 log units) below; the measured number falls inside the stated range.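

In this assay, compound 4 is the first compound shown to give a number and not a limit, at 5000 nM. Among these compounds, putting cyclohexyl in place of phenyl on the amide-type nitrogen gives a number no lower from compound 3 to compound 4 (the limit leaves the size open), so this is the first change with any readable direction, while the three earlier steps, all made on an aromatic carbon, cannot be read. The change does not show a clear separation from the rest of the series, since the number for compound 4 is the same figure as the limit that the other compounds share: the limit of < 5000 nM in this assay, at which 3 of the 4 values shown sit.

On these data alone, how far compound 4 really stands from compound 3 remains open, and so does whether the same swap on the amide-type nitrogen would give a readable number with the other groups carried by compound 1 and compound 2. Also open, as far as these compounds go, is what this position would do with an open alkyl chain, a cyclohexyl ring carrying an amine or a carboxylic acid, or a saturated ring containing oxygen, such as tetrahydropyranyl.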